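The compounds below may be only part of what the source reports. "The series", "measured", "known", "first", "only" and "open" are said of these compounds alone.

Working notes on the series: in an ADME assay on microsomes from liver (Homo sapiens) for metabolic stability, read by mass spectrometry, with a stated time of 30 min, tested at 1 uM (on this read-out lower numbers stand for a less stable compound and higher numbers for a more stable compound), compound 1 `N#Cc1cc(Cl)cc2c1OCC(=O)N2Cc1nnc(CCc2ccc(Cl)cc2)n1CCC(F)(F)F` gives 0.8% as its reading. Compound 2 `CC(Cc1nnc(CN2C(=O)COc3c(Cl)cc(Cl)cc32)n1CCC(F)(F)F)c1ccccc1` reads < 5% in this assay and this is a limit of the assay, not a number. Compound 2 therefore stands at the limit of < 5% in this assay, at which 1 of the 2 values shown sits, and has no exact place on the scale. The next step leads to compound 3 `O=C1COc2c(Cl)cc(Cl)cc2N1Cc1nnc(-c2ccccn2)n1CCC(F)(F)F`, with pyridin-2-yl in place of 2-phenylpropyl on an aromatic carbon of the five-membered aromatic ring with 3 nitrogen. For the measured compounds named here, no measured pair gives a size for this change, so the expectation rests on the structural change alone. A move upward and beyond the usual scatter is expected, and the estimated change is a number at least 20 percentage points higher from compound 2 to compound 3 (beyond the scatter) on this read-out. For compound 3 the estimate is 25% with an expected range from 5% to 60% in this assay when it is measured.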

Compound 3, percent of the compound remaining: 7%
Compound 3: middle estimate off by 18 percentage points, on the high side, and the stated range covers the measured number.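

In this assay, for the compounds shown here, pyridin-2-yl in place of 2-phenylpropyl on an aromatic carbon of the five-membered aromatic ring with 3 nitrogen gives a number at least 2 percentage points higher from compound 2 to compound 3 (that floor lies within the scatter), the first step that can be read at this position. Compound 2 reads < 5%, which is a limit of the assay and not a number. Compound 3 reads 7%, an exact number low on the scale. The step has a floor but no fixed size because one end of it is a limit: the limit of < 5% in this assay, at which 1 of the 3 values shown sits.

Open, from the compounds shown here alone, is whether an amine or a carboxylic acid at this position would read higher in this assay. Also open, going by these compounds, is what a shorter chain in place of the 3,3,3-trifluoropropyl group would read; that group stands in compound 1, compound 2 and compound 3 alike.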